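One Stereocentre Changed at the Limit of the Assay

The source may report more compounds than this note shows. Statements on the series, on what has been measured and on what is new or still open speak of the compounds shown alone.

In an ADME assay on KB cells (Homo sapiens) for cytotoxicity, with a stated time of 48 h (a higher number here means a weaker inhibitor, a lower number a stronger inhibitor), compound 2 (`C=C1[C@H](C)CCC[C@]1(C)CC/C(C)=C/CC1=C(O)C(=O)C=C(N[C@H](CO)C(=O)O)C1=O`) gives > 10 ug/mL as a limit and not a number. Compound 1 (`CC1=CCC[C@](C)(CC/C(C)=C/CC2=C(O)C(=O)C=C(N[C@H](C(=O)O)[C@@H](C)O)C2=O)[C@@H]1C`) gives > 10 ug/mL as a limit too. Compound 3 (`CC1=CCC[C@](C)(CC/C(C)=C/CC2=C(O)C(=O)C=C(N[C@@H](C(=O)O)C(C)C)C2=O)[C@@H]1C`) gives > 10 ug/mL as a limit as well. For the measured compounds named here, the one measured step is a step that the two limits leave unreadable from compound 1 to compound 3 and it concerns a different change. Going by the values given here, in compound 4 (`C=C1[C@H](C)CCC[C@]1(C)CC/C(C)=C/CC1=C(O)C(=O)C=C(N[C@@H](CO)C(=O)O)C1=O`) the change from compound 2 is this: the two compounds have the same atoms and bonds and differ only in configuration as drawn: 1 of 4 stereo elements differ; a stereocentre at a saturated chain carbon is drawn R in compound 2 and S in compound 4 and no measured step tests such a change. Compound 2 sits with the others at the limit of > 10 ug/mL in this assay, at which 3 of the 3 values shown sit, so no step beyond the scatter is expected. The expected step is a step that the limit leaves unreadable from compound 2 to compound 4 in this assay with no direction foreseen. Compound 4 is estimated at 15 ug/mL with an expected range of 7 ug/mL to 40 ug/mL and most likely only a limit reported.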

Compound 4, half-maximal inhibitory concentration: > 10 ug/mL
Compound 4 was reported as a limit (the forecaster's own chance of this, stated with the estimate: 85%); the middle value is on the limit's open side.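

No step between compound 2 and compound 4 can be read in this assay: the limit of > 10 ug/mL in this assay, at which 4 of the 4 values shown sit.

Left open is whether drawing that saturated chain carbon as R or S affects cytotoxicity at all, as every compound shown gives only a limit.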